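The compounds below may be only part of what the source reports. "The series", "measured", "known", "first", "only" and "open" are said of these compounds alone.

Measured compounds:
Compound 1 `Cc1cccc(NC(=O)CSC(=S)N[C@H]2CCOC2=O)c1C` in a functional assay on MCF7 cells (Homo sapiens) for cytotoxicity, read by MTT assay, with a stated time of 72 h (on this read-out lower numbers stand for stronger inhibition and higher numbers for weaker inhibition), gives > 128000 nM, which is a limit of the assay rather than a number.
Compound 2 `COc1ccc(NC(=O)CSC(=S)N[C@H]2CCOC2=O)cc1` in this assay gives > 128000 nM, which is likewise a limit of the assay rather than a number.

Both measured values sit at the limit of > 128000 nM in this assay, at which 2 of the 2 values shown sit, so neither compound is placed on a number at all, and compound 2 stands only at that limit; the two values show the same outcome and allow no order between them. Among the compounds with values here, no step between measured compounds is available in this set, since neither value is a number.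

Compound 3 `CCCCc1ccc(NC(=O)CSC(=S)N[C@H]2CCOC2=O)cc1` is the next member. It differs from compound 2 by butyl in place of methoxy on an aromatic carbon. With two limits as the only data, no measured step sets the direction or the size of what this change does in this assay, and no reason for any shift can be drawn from the compounds shown. Compound 3 is therefore expected to sit at about 150000 nM, within 60000 nM to 400000 nM, and most likely to be reported once more only as a limit. The step that this estimate means, a step that the limit leaves unreadable from compound 2 to compound 3, is expected to be none beyond the scatter.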

Compound 3, half-maximal inhibitory concentration: 40200 nM
Estimate against measurement, compound 3: 3.7-fold (0.57 log units) above; measured number outside the range, below it.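

On the shared core, the place para to a large group proves able to move the read-out: in this assay, butyl in place of methoxy on an aromatic carbon gives an at least 3.1-fold lower number from compound 2 to compound 3 (0.50 log units; beyond the scatter). This is the first sign in the set that the group at this place matters for the cytotoxicity seen in these cells, and compound 3, at 40200 nM, is the only compound shown that carries a number rather than a limit. The step remains a lower bound on the size of the change and not a size, no step involving compound 1 can be read, and the other values offer no second number to compare with: the limit of > 128000 nM in this assay, at which 2 of the 3 values shown sit.

Within the data shown here, the single pair cannot tell whether the shift follows from the entry of butyl, from the departure of methoxy or from both, and a plain hydrogen at this place would be needed to separate the two. Nor does it show whether the trend continues with a longer chain such as hexyl, or whether a shorter chain such as ethyl, or an amine or a carboxylic acid at the same place, would leave the number at the limit.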